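The source may report more compounds than this note shows. Statements on the series, on what has been measured and on what is new or still open speak of the compounds shown alone.

Measured so far in a functional assay on ONS-76 cells (Homo sapiens) for cytotoxicity, read by MTT assay, with a stated time of 72 h; a higher number here means a weaker inhibitor, a lower number a stronger inhibitor:
- Compound 1 `COc1ccc(N(C)C(=O)N(C)c2cc(OC)c(OC)c(OC)c2)cc1` is reported only as a limit of this assay, >= 125000 nM.
- Compound 2 `COc1cc(NC(=O)c2cccc([N+](=O)[O-])c2)cc(OC)c1OC` is likewise reported only as a limit, >= 125000 nM.
- Compound 3 `COc1cc(NC(=O)Nc2cccc3c2CCC3)cc(OC)c1OC` is also reported only as a limit, >= 125000 nM.

Compound 2 therefore stands nowhere in particular on the numbers shown: its value is a limit and not a number, and the same holds for the two other measured compounds, so that the limit of >= 125000 nM in this assay, at which 3 of the 3 values shown sit, describes the whole set. Among the measured compounds shown here, no step between two measured compounds is available, and nothing can be read about how any change moves the read-out.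

Compound 4 `COc1cc(N(C)C(=O)c2cccc([N+](=O)[O-])c2)cc(OC)c1OC` is the next compound in this assay. It differs from compound 2 by methyl in place of hydrogen on an amide-type nitrogen. For the measured compounds named here, since compound 2 gives only a limit, there is no measured step to lean on. The expectation is that compound 4 also sits at the limit, and the step of a number no higher from compound 2 to compound 4 (the limit leaves the size open) is expected to be none beyond the scatter. The estimate for compound 4 in this assay is 125000 nM, with a range from 60000 nM to 300000 nM.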

Compound 4, half-maximal inhibitory concentration: >= 125000 nM
Compound 4: no number, only a limit; the forecaster's own chance of this, stated with the estimate: 80%; the middle value lies on the limit itself.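

Compound 2 and compound 4 are both reported only as limits in this assay, so no step can be read for methyl in place of hydrogen on the amide-type nitrogen: the limit of >= 125000 nM in this assay, at which 4 of the 4 values shown sit.

The compounds shown leave open which structural change, if any, would give a measurable number in this assay.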